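Benzyloxy for Fluoro at the Fused Ring of Compound 3

The source may hold more compounds than are shown below. What is called first, only, known or untested is meant among the compounds shown, and "the series" means these compounds.

Of the compounds shown here, three from one series have been measured in an assay on HeLa cells for binding affinity to 5-hydroxytryptamine receptor 6 (Homo sapiens); on this read-out lower numbers stand for stronger inhibition and higher numbers for weaker inhibition. Compound 1 `Nc1ccc(S(=O)(=O)n2cc(C3=CCNCC3)c3cc([N+](=O)[O-])ccc32)cc1` gives 29 nM. Compound 2 `O=S(=O)(c1ccc2ccccc2c1)n1cc(C2=CCNCC2)c2ccccc21`, which differs from the others at several positions, gives 27 nM. Compound 3 `Nc1ccc(S(=O)(=O)n2cc(C3=CCNCC3)c3cc(F)ccc32)cc1` gives 1 nM, the lowest number of the three, and its values against compound 1 and compound 2 both sit well beyond the scatter, so compound 3 is the most potent of the measured set in this assay.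

Compound 4 `Nc1ccc(S(=O)(=O)n2cc(C3=CCNCC3)c3cc(OCc4ccccc4)ccc32)cc1` has not yet been measured. Its difference from compound 3 is benzyloxy in place of fluoro on an aromatic carbon. Among the measured compounds shown here, only one measured step touches the same carbon: a 29-fold lower number from compound 1 to compound 3 (1.46 log units; beyond the scatter). That step shows the position to be highly sensitive to what is placed there, but it compares nitro with fluoro and says nothing directly about benzyloxy. For the measured compounds named here, no measured compound carries a group of comparable size at that carbon, so the direction of the change rests on weak ground. Given the large sensitivity seen in compound 1 with a 29-fold lower number from compound 1 to compound 3 (1.46 log units; beyond the scatter), a step towards a higher number is expected for compound 4, of the size a 10-fold higher number from compound 3 to compound 4 (1.00 log units; beyond the scatter). Compound 4 is therefore estimated at 10 nM in this assay, within a range from 2 nM to 60 nM.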

Compound 4, inhibition constant: 50 nM
Estimate against measurement, compound 4: 5.0-fold (0.70 log units) below; the range from low to high includes it.
By their numbers in this assay, from the lowest: compound 3; then compounds 2, 1 and 4 (each within the scatter of the next).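

In this assay, the change from fluoro to benzyloxy, which brings 8 heavy atoms and a six-membered aromatic ring of carbon only in place of a single fluorine, gives a 50-fold higher number from compound 3 to compound 4 (1.70 log units; beyond the scatter), a large step and the first measured at this carbon that starts from fluoro. The comparison with the nitro compound gives a 1.7-fold higher number from compound 1 to compound 4 (0.24 log units; within the scatter), which lies within the scatter, so nitro and benzyloxy cannot be told apart here and, of the three groups measured on this carbon, fluoro alone gives a clearly lower number. Nothing in hand explains why these groups give the numbers they do.

The compounds shown leave open where between these values a methoxy group, a chlorine or plain hydrogen on the same carbon would fall, and so whether the low number of compound 3 is particular to fluoro or shared with other groups. They also leave open whether a longer chain ending in an amine on this carbon would stay level with compound 4 or move away from it.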